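Aryl variation on the triazole nitrogen: cytotoxicity notes

The source may report more compounds than this note shows. Statements on the series, on what has been measured and on what is new or still open speak of the compounds shown alone.

Three compounds share one core and differ only in the aryl group on the triazole nitrogen. In a functional assay on HeLa cells (Homo sapiens) for cytotoxicity, read by MTT assay, with a stated time of 48 h (a lower number here means a stronger inhibitor, a higher number a weaker inhibitor), compound 1 `Cc1cccc(-n2cc(COC(=O)c3cc4ccccc4[nH]3)nn2)c1C` gives 30300 nM, compound 2 `Cc1cc(C)cc(-n2cc(COC(=O)c3cc4ccccc4[nH]3)nn2)c1` gives 30200 nM, and compound 3 `COc1ccc(-n2cc(COC(=O)c3cc4ccccc4[nH]3)nn2)cc1` gives 16100 nM. The steps of a 1.0-fold lower number from compound 1 to compound 2 (0.00 log units; within the scatter), a 1.9-fold lower number from compound 1 to compound 3 (0.27 log units; within the scatter) and a 1.9-fold lower number from compound 2 to compound 3 (0.27 log units; within the scatter) all stay within the scatter, so compound 3 stands together with the other two rather than apart from them. Compound 4 `O=C(OCc1cn(-c2ccccc2Br)nn1)c1cc2ccccc2[nH]1` carries 2-bromophenyl in place of 4-methoxyphenyl on an aromatic nitrogen. Within the data shown here, the only steps that bear on this change are the aryl swaps above, none of which moved the number beyond the scatter, so for compound 4 no step beyond the scatter is expected in this assay, in either direction. Compound 4 is therefore estimated at 22000 nM, with a range of 8000 nM to 60000 nM, an expected step of a 1.4-fold higher number from compound 3 to compound 4 (0.14 log units; within the scatter).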

Compound 4, half-maximal inhibitory concentration: 17300 nM
Compound 4: the middle estimate sits 1.3-fold (0.10 log units) above what was measured; the measured number falls inside the stated range.
By their numbers in this assay, from the lowest: compounds 3, 4, 2 and 1 (each within the scatter of the next).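

The 2-bromophenyl group brings in bromine, and in this assay it stays within the scatter of all three earlier aryl groups (a 1.1-fold higher number from compound 3 to compound 4 (0.03 log units; within the scatter); a 1.7-fold lower number from compound 2 to compound 4 (0.24 log units; within the scatter); a 1.8-fold lower number from compound 1 to compound 4 (0.24 log units; within the scatter)). Even the exchange of 4-methoxyphenyl, with its counted hydrogen-bond acceptor, for 2-bromophenyl, with none, leaves the number within the scatter. No measurement explaining this flat response is available.

Open, on these data alone, is whether a phenyl ring carrying an amine or a carboxylic acid, or a longer chain on the aromatic nitrogen, would step beyond the scatter.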